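The source may report more compounds than this note shows. Statements on the series, on what has been measured and on what is new or still open speak of the compounds shown alone.

Measured in a functional assay on A549 cells (Homo sapiens) for antiproliferative activity, read by MTT assay, with a stated time of 48 h; on this read-out higher numbers stand for weaker inhibition and lower numbers for stronger inhibition:
- compound 1 `Cc1c(C(=O)NCCCN(C)C)oc2ccc(N(Cc3ccc(Br)cc3)S(=O)(=O)c3ccc(Br)cc3)cc12`: 4310 nM
- compound 2 `Cc1c(C(=O)OCCCN(C)C)oc2ccc(N(Cc3ccc(Br)cc3)S(=O)(=O)c3ccc(Br)cc3)cc12`: > 40000 nM

Compound 2 gives > 40000 nM, and this is a limit of the assay, not a number. Its true position is therefore unknown, and it may be anywhere on the weak side of that limit.

The next compound is compound 3 `Cc1c(C(=O)NCC(O)CO)oc2ccc(N(Cc3ccc(Br)cc3)S(=O)(=O)c3ccc(Br)cc3)cc12`. The change is (2,3-dihydroxypropyl)amino in place of 3-(dimethylamino)propoxy on a carbonyl carbon.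

For the measured compounds named here, only one measured step bears on this change: an at least 9.2-fold higher number from compound 1 to compound 2 (0.96 log units; beyond the scatter), in which 3-(dimethylamino)propoxy took the place of (3-(dimethylamino)propyl)amino. Read backwards, that step suggests that an amino group on the carbonyl carbon could bring the number down again. However, compound 3 also lacks the dimethylamino end, and no measured step shows what losing it does. Compound 1 at 4310 nM is therefore only a loose guide, and a smaller gain is expected.

The expected change is an at least 2.6-fold lower number from compound 2 to compound 3 (0.42 log units; beyond the scatter), an estimate pointing towards stronger inhibition, though the result could stay at the limit. For compound 3 the estimated value is 15000 nM, with an expected range of 5000 nM to 40000 nM.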

Compound 3, half-maximal inhibitory concentration: 30500 nM
Compound 3: the middle estimate sits 2.0-fold (0.31 log units) below what was measured; measured number inside the range.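

In this assay, keeping the amide link while changing the end of the chain has a clear cost: a 7.1-fold higher number from compound 1 to compound 3 (0.85 log units; beyond the scatter), with 1,2-dihydroxyethyl in place of 2-(dimethylamino)ethyl. For the compounds shown here, the earlier comparison, an at least 9.2-fold higher number from compound 1 to compound 2 (0.96 log units; beyond the scatter), changed only the link to the carbonyl carbon, so this is the first sign that the chain end matters here too, and that an amide link alone does not restore the value of compound 1. The comparison with the ester is much less informative, since an at least 1.3-fold lower number from compound 2 to compound 3 (0.11 log units; that floor lies within the scatter) gives only a floor, and the order of these two compounds stays unsettled because compound 2 is recorded as a limit and not as a number: the limit of > 40000 nM in this assay, at which 1 of the 3 values shown sits.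

From the compounds shown here alone, it remains open whether the loss in compound 3 comes from removing the dimethylamino group or from adding the two hydroxyl groups, which a plain propyl chain or a chain with a single hydroxyl group could help to separate. Going by these compounds, it is also open how specific the dimethylamino end is, a question that a primary amine, a carboxylic acid or a longer chain at this place could address.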